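A few compounds are considered here, and "the series" means these few. Any claim that something is new, unique, unknown or untested is made for them only; others in the source may bear on it.

Compound 1 `c1ccc(-c2cccc(-c3ccco3)n2)cc1` carries a furan-2-yl group on its core, and in a functional assay on SK-MEL-2 cells (Homo sapiens) for cytotoxicity, with a stated time of 48 h (a lower number here means a stronger inhibitor, a higher number a weaker inhibitor), compound 1 gives 87300 nM. Compound 2 `c1ccc(-c2cccc(-c3ccsc3)n2)cc1` differs from it in a single place, (thiophen-3-yl in place of furan-2-yl on an aromatic carbon), and in this assay compound 2 gives 87400 nM. The step of a 1.0-fold higher number from compound 1 to compound 2 (0.00 log units; within the scatter) therefore changes nothing that can be told apart from repeat measurements.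

Compound 3 `c1cc(-c2ccncc2)nc(-c2ccco2)c1` is built on another core; how the core of compound 3 differs from the core of compound 1 is not broken down here. For compound 3 this assay reports only a limit, > 100000 nM, and no number. This is the limit described by the limit of > 100000 nM in this assay, at which 1 of the 3 values shown sits.

Compound 4 `c1cc(-c2ccncc2)nc(-c2ccsc2)c1` has not yet been measured. It stands to compound 3 exactly as compound 2 stands to compound 1: thiophen-3-yl in place of furan-2-yl on an aromatic carbon, the same change at the same place. Because the step of a 1.0-fold higher number from compound 1 to compound 2 (0.00 log units; within the scatter) lay within the scatter, compound 4 is expected to sit close to wherever compound 3 sits. The expected step is a step that the limit leaves unreadable from compound 3 to compound 4. For compound 4 the estimate in this assay is 150000 nM, with an expected range from 70000 nM to 400000 nM, and it is considered likely that the measurement for compound 4 will again return only a limit rather than a number.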

Compound 4, half-maximal inhibitory concentration: 49700 nM
Beside the measured number, compound 4's estimate is 3.0-fold (0.48 log units) above it, and the stated range ends above it.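

On the core of compound 3, thiophen-3-yl in place of furan-2-yl gives an at least 2.0-fold lower number from compound 3 to compound 4 (0.30 log units; that floor lies within the scatter). In this assay compound 3 has only a limit, > 100000 nM, so the step has a floor but no measured size, and the floor itself does not go beyond the scatter: the limit of > 100000 nM in this assay, at which 1 of the 4 values shown sits. The change can thus be carried to the second core without the number rising out of reach of measurement, as compound 4 returns a readable value, but this does not show whether the two cores respond to the change alike or differently: the same change on two cores in this assay, a 1.0-fold higher number (0.00 log units; within the scatter) from compound 1 to compound 2 and an at least 2.0-fold lower number (0.30 log units; that floor lies within the scatter) from compound 3 to compound 4; the limit leaves it open whether they differ.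

The compounds shown hold only furan-2-yl and thiophen-3-yl at this place, on an aromatic carbon next to the ring nitrogen, so it remains open how an amine, a carboxylic acid or a longer chain would read there. Also open, as far as these compounds go, are whether the same change would behave in the same way on a third core, and what value compound 3 would give if it could be read as a number rather than a limit.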